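Swapping selenium for sulfur on a shared acyl-imine carbon

A few compounds are considered here, and "the series" means these few. Any claim that something is new, unique, unknown or untested is made for them only; others in the source may bear on it.

Compound 1 `C[Se]/C(=N\C(=O)c1ccco1)NC(=O)c1ccco1` and compound 2 `CS/C(=N\C(=O)c1ccco1)NC(=O)c1ccco1` share one core, and in a functional assay on MCF7 cells (Homo sapiens) for cytotoxicity, read by MTT assay, with a stated time of 72 h (a lower number here means a stronger inhibitor of growth, a higher number a weaker inhibitor of growth), compound 1 gives 88900 nM. In this assay compound 2 gives > 100000 nM, which is a limit of the measurement rather than a number. The change between the two is a group of 2 heavy atoms (1 carbon, 1 sulfur; no ring) in place of a group of 2 heavy atoms (1 carbon, 1 selenium; no ring), on a carbon with a double bond to nitrogen, and it produced a step of an at least 1.1-fold higher number from compound 1 to compound 2 (0.05 log units; that floor lies within the scatter), a floor that follows from the limit of > 100000 nM in this assay, at which 1 of the 3 values shown sits. Compound 3 `C[Se]/C(=N\C(=O)c1cnc2ccccc2c1)NC(=O)c1cnc2ccccc2c1` stands on a different core; how that core differs from the core of compound 1 is not broken down here. In this assay compound 3 gives 8030 nM, a lower number than compound 1 reaches. Compound 4 `CS/C(=N\C(=O)c1cnc2ccccc2c1)NC(=O)c1cnc2ccccc2c1` relates to compound 3 through (a group of 2 heavy atoms (1 carbon, 1 sulfur; no ring) in place of a group of 2 heavy atoms (1 carbon, 1 selenium; no ring), on a carbon with a double bond to nitrogen), the same change as before, at the same place. For compound 4 the expected step is a 2.5-fold higher number from compound 3 to compound 4 (0.40 log units; beyond the scatter), resting on the earlier step of an at least 1.1-fold higher number from compound 1 to compound 2 (0.05 log units; that floor lies within the scatter), whose size is known only as a floor. Compound 4 is therefore estimated at 20000 nM, with an expected range from 8000 nM to 60000 nM.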

Compound 4, concentration for total growth inhibition: > 100000 nM
Compound 4 ended at the assay's limit (the forecaster's own chance of this, stated with the estimate: 10%); at least 5.0-fold (0.69 log units) between middle value and limit.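

In this assay compound 4 gives > 100000 nM, which is a limit of the assay and not a number. Even so, the step can be read as a lower bound: putting methylsulfanyl in place of the selenium group, on a carbon with a double bond to nitrogen, gives an at least 12-fold higher number from compound 3 to compound 4 (1.09 log units; beyond the scatter), so on this core the selenium compound is clearly the stronger inhibitor of growth. This does not show that the change has the same effect on both cores, nor that its effect depends on the core: the same change on two cores in this assay, an at least 1.1-fold higher number (0.05 log units; that floor lies within the scatter) from compound 1 to compound 2 and an at least 12-fold higher number (1.09 log units; beyond the scatter) from compound 3 to compound 4; the limit leaves it open whether they differ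

The true size of each step stays unknown, as neither sulfur compound has a measured value: the limit of > 100000 nM in this assay, at which 2 of the 4 values shown sit. The compounds shown also leave open what happens when a longer chain such as ethyl replaces the methyl on the selenium or sulfur, or when an amine takes the place of the whole group on that carbon.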